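From 2,5-dimethoxyphenyl to 3,4-dimethoxyphenyl at the assay limit

The compounds below may be only part of what the source reports. "The series", "measured", "known", "first", "only" and "open" are said of these compounds alone.

Values so far in a functional assay on PC-3 cells (Homo sapiens) for cytotoxicity, read by MTT assay, with a stated time of 48 h; on this read-out lower numbers stand for stronger inhibition and higher numbers for weaker inhibition:
Compound 1 `COc1ccc(/C=C/C(=O)/C=C/c2cc3ccccc3nc2Oc2ccc(Br)cc2)cc1OC` gives > 10000 nM as a limit
Compound 2 `COc1ccc(/C=C/C(=O)/C=C/c2cc3ccccc3nc2Oc2cccc(Cl)c2)c(OC)c1` gives > 10000 nM as a limit
Compound 3 `COc1ccc(OC)c(/C=C/C(=O)/C=C/c2cc3ccccc3nc2Oc2cccc(Cl)c2)c1` gives > 10000 nM as a limit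

Compound 3 therefore stands at a limit and has no number in this assay. Compound 4 `COc1ccc(/C=C/C(=O)/C=C/c2cc3ccccc3nc2Oc2cccc(Cl)c2)cc1OC`, not yet measured, brings (3,4-dimethoxyphenyl in place of 2,5-dimethoxyphenyl on a double-bonded chain carbon bound to a double-bonded chain carbon), with 3,4-dimethoxyphenyl in place of 2,5-dimethoxyphenyl. Among the compounds with values here, the one measured step, a step that the two limits leave unreadable from compound 2 to compound 3, gives no size to build on. All the data sit at one value, (the limit of > 10000 nM in this assay, at which 3 of the 3 values shown sit). Compound 1 also carries 3,4-dimethoxyphenyl and gives > 10000 nM, again a limit. No clear change is therefore expected, only an estimated step that the limit leaves unreadable from compound 3 to compound 4 with no firm direction. For compound 4 the estimate is 12000 nM, with an expected range from 4000 nM to 30000 nM.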

Compound 4, half-maximal inhibitory concentration: > 10000 nM
Compound 4: a limit, no number (the forecaster's own chance of this, stated with the estimate: 75%); the middle value does not contradict the limit.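

In this assay, compound 4 stands only at a limit, like compound 1, compound 2 and compound 3, so no step to compound 4 can be read: the limit of > 10000 nM in this assay, at which 4 of the 4 values shown sit.

The compounds shown leave open whether 2,4-dimethoxyphenyl, 2,5-dimethoxyphenyl and 3,4-dimethoxyphenyl differ at all in this assay.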